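The compounds below may be only part of what the source reports. "The series", "measured", "known", "first", "only" and "open" are said of these compounds alone.

Compound 3, with structure `O=c1[nH]c(=O)n([C@@H]2CO[C@H](CO)O2)cc1/C=C/Br`, is measured in a functional assay on Vero cells (Chlorocebus sabaeus) for cytotoxicity; a lower number here means that less compound is tolerated, a higher number that more compound is tolerated. In this assay compound 3 gives 100 ug/mL, level at the digits shown with compound 2, whose structure is `O=c1[nH]c(=O)n([C@H]2CO[C@@H](CO)S2)cc1/C=C/Br` and which gives 100 ug/mL; together these are the highest of the three numbers so far. Compound 1, structure `O=c1[nH]c(=O)n([C@@H]2CO[C@@H](CO)S2)cc1/C=C/Br`, gives 30 ug/mL, and the step of a 3.3-fold higher number from compound 1 to compound 2 (0.52 log units; beyond the scatter) lies beyond the scatter.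

Compound 4, structure `O=c1[nH]c(=O)n([C@@H]2CO[C@@H](CO)O2)cc1/C=C/Br`, has not yet been measured. It differs from compound 3 as follows: the two compounds have the same atoms and bonds and differ only in configuration as drawn: 1 of 3 stereo elements differ; a stereocentre at a saturated ring carbon is drawn S in compound 3 and R in compound 4.

Within the data shown here, one measured step bears on this change. Compounds 1 and 2 are related by the fact that compounds 1 and 2 differ only in the configuration as drawn, and the step of a 3.3-fold higher number from compound 1 to compound 2 (0.52 log units; beyond the scatter) shows that a change of configuration alone at a saturated ring carbon can shift the number in this assay, in that case to a higher one. The flip from compound 3 to compound 4 is of the same kind, though at a different ring carbon, so a step of comparable size in either direction cannot be ruled out.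

Compound 4 is therefore expected to give about 100 ug/mL in this assay, within a range of 30 ug/mL to 300 ug/mL, which means an expected step of no change at the digits printed from compound 3 to compound 4 (within the scatter).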

Compound 4, half-maximal cytotoxic concentration: 100 ug/mL
For compound 4 middle estimate and measured number coincide at the digits printed, within the range that was stated.
By their numbers in this assay, from the lowest: compound 1; then compounds 2, 3 and 4 (each within the scatter of the next).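

The new step, no change at the digits printed from compound 3 to compound 4 (within the scatter), gives the first view of a configuration flip at this saturated ring carbon, and in this assay it leaves the number where it was. The only earlier flip, a 3.3-fold higher number from compound 1 to compound 2 (0.52 log units; beyond the scatter), had shown that configuration alone can move the number beyond the scatter, so the new pair shows that this does not hold for every such flip among these compounds. This reading rests on a comparison in which no atom or bond changes, only the arrangement at one carbon: the fact that compounds 3 and 4 differ only in the configuration as drawn

The two flips sit at different ring carbons, and the core of compounds 1 and 2 carries a sulfur atom where that of compounds 3 and 4 carries an oxygen atom, so these pairs cannot tell which of the two differences goes with the contrast in their steps. As far as these compounds go, it also stays open whether this ring carbon would remain as indifferent to its configuration with an amine or a carboxylic acid in place of the hydroxymethyl group, or with a longer chain in place of the bromovinyl group.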